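This account rests on a few compounds, and the source may have more. Where it says the series, first, only, none or still open, it means among the compounds named here.

In a functional assay on HT-1080 cells (Homo sapiens) for cytotoxicity, read by MTT assay, with a stated time of 72 h (a lower number here means a stronger inhibitor, a higher number a weaker inhibitor), compound 1 (`COc1cccc(/C=C2\CCC/C(=C\c3cccc(Br)c3)C2=O)c1OC`) gives 12200 nM, and compound 2 (`COc1cccc(/C=C2\CCC/C(=C\c3ccc(Br)cc3)C2=O)c1OC`) gives 13700 nM, so the two stand level within the scatter. The next compound to be tested is compound 3 (`COc1cccc(/C=C2\CCC/C(=C\c3ccc(O)cc3)C2=O)c1OC`), which has 4-hydroxyphenyl in place of 3-bromophenyl on a double-bonded chain carbon bound to a double-bonded ring carbon. For the measured compounds named here, only one measured step bears on this change, the exchange of 3-bromophenyl for 4-bromophenyl at the same place, which amounts to a 1.1-fold higher number from compound 1 to compound 2 (0.05 log units; within the scatter). Going by the values given here, that step shows that the number held steady between these two bromophenyl groups, but it offers only limited guidance, since no measured compound carries 4-hydroxyphenyl. With no measured step beyond the scatter, the data give no ground for expecting a clear move in either direction. The expected outcome in this assay is a 1.2-fold lower number from compound 1 to compound 3 (0.09 log units; within the scatter), which is no real change. For compound 3 the estimated value is 10000 nM, with an expected range from 4000 nM to 25000 nM.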

Compound 3, half-maximal inhibitory concentration: > 20000 nM
Compound 3: a limit, no number; the forecaster's own chance of this, stated with the estimate: 10%; middle value at least 2.0-fold (0.30 log units) from the limit.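

For compound 3, this assay returns a limit and not a number: the limit of > 20000 nM in this assay, at which 1 of the 3 values shown sits. Read as floors only, the new steps are an at least 1.6-fold higher number from compound 1 to compound 3 (0.21 log units; that floor lies within the scatter) and an at least 1.4-fold higher number from compound 2 to compound 3 (0.16 log units; that floor lies within the scatter), so neither establishes a real difference, although the true size of each step could be larger than its floor. Where the earlier pair gave only a 1.1-fold higher number from compound 1 to compound 2 (0.05 log units; within the scatter), with bromo on both phenyl groups, this is the first change at this place, on a double-bonded chain carbon bound to a double-bonded ring carbon, that gives no upper bound: hydroxy in place of bromo on an aromatic carbon might leave the number within the scatter or might move it much further, and the limit cannot separate those two readings.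

The compounds shown leave open whether the result for 4-hydroxyphenyl belongs to the hydroxy group itself or to its ring position, as 3-hydroxyphenyl does not stand among them. They also leave open how 4-methoxyphenyl, 4-aminophenyl or a phenyl ring bearing a carboxylic acid would read at this place.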